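Imidazoline series: pyridine nitrogen position at the amidine carbon

This account rests on a few compounds, and the source may have more. Where it says the series, first, only, none or still open, it means among the compounds named here.

Compound 1 `O=Cc1cccc(C2=NC(c3ccc(F)cc3)(c3ccc(F)cc3)CN2)c1` is the reference point of the pair measured so far: in an assay on LM cells for displacement of a labelled ligand from Neuropeptide Y receptor type 5 (Homo sapiens) (on this read-out lower numbers stand for stronger inhibition and higher numbers for weaker inhibition), compound 1 gives 8.7 nM. Compound 2 `Fc1ccc(C2(c3ccc(F)cc3)CNC(c3ccccn3)=N2)cc1` carries pyridin-2-yl in place of the 3-formylphenyl group; in this assay compound 2 gives 160 nM. The step of an 18-fold higher number from compound 1 to compound 2 (1.26 log units; beyond the scatter) is the only measured step in the set, and it leaves compound 2 with the highest of the two numbers shown.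

Compound 3 `Fc1ccc(C2(c3ccc(F)cc3)CNC(c3cccnc3)=N2)cc1` is the next member; it differs from compound 2 by pyridin-3-yl in place of pyridin-2-yl on a carbon with a double bond to nitrogen. Within the data shown here, no measured step bears directly on moving the ring nitrogen within a pyridine; the single step on record swaps a whole aryl group for another and was large. On that basis a change beyond the scatter cannot be ruled out for compound 3, but there is no measured ground for a firm direction, so the expectation stays close to compound 2, with a wide range. Compound 3 is estimated at 80 nM (range 15 nM to 400 nM), an expected step of a 2.0-fold lower number from compound 2 to compound 3 (0.30 log units; within the scatter).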

Compound 3, half-maximal inhibitory concentration: 7.2 nM
For compound 3 the middle estimate is 11-fold (1.05 log units) above the measured one, outside the stated range (below it).
By their numbers in this assay, from the lowest: compounds 3 and 1 (each within the scatter of the next); then compound 2.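

The earlier step replaced a whole aryl group, whereas this one keeps the same atoms and moves only the ring nitrogen: in this assay pyridin-3-yl in place of pyridin-2-yl gives a 22-fold lower number from compound 2 to compound 3 (1.35 log units; beyond the scatter) and so shows that this position, between two ring nitrogen atoms, separates these two pyridine isomers sharply. The change from 3-formylphenyl to pyridin-3-yl gives a 1.2-fold lower number from compound 1 to compound 3 (0.08 log units; within the scatter) and stays within the scatter, so the higher number of compound 2 does not extend to both pyridines shown and the formyl group is not needed to reach the level of compound 1. No outside evidence bears on this result.

From the compounds shown here alone, it remains open whether pyridin-4-yl at the same place would fall with pyridin-3-yl or with pyridin-2-yl. Going by these compounds, it also remains open how a phenyl ring carrying an amine or a carboxylic acid in place of the formyl group would compare with compound 1 and compound 3.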